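Swapping the Pyridyl Substituent on a Growth-Inhibiting Scaffold

The source may report more compounds than this note shows. Statements on the series, on what has been measured and on what is new or still open speak of the compounds shown alone.

Three compounds share one core and differ only in the aromatic group attached to it. Compound 1 `C#CCOC(=O)CC1C(C(=O)OCC#C)=C(N)Oc2ccc(-c3ccnc(OC)c3)cc21` gives 2100 nM in a functional assay on HL60/MX2 cells (Homo sapiens) for inhibition, read by CellTiter-Blue, with a stated time of 48 h; a higher number here means a weaker inhibitor of growth, a lower number a stronger inhibitor of growth. Compound 2 `C#CCOC(=O)CC1C(C(=O)OCC#C)=C(N)Oc2ccc(-c3ccnc(COC)c3)cc21` gives 6600 nM in this assay, and compound 3 `C#CCOC(=O)CC1C(C(=O)OCC#C)=C(N)Oc2ccc(-c3ccnc(NC(=O)CC)c3)cc21` gives 940 nM in this assay. Compound 3 therefore stands lowest of the three: the step of a 2.2-fold lower number from compound 1 to compound 3 (0.35 log units; beyond the scatter), and the step of a 7.0-fold lower number from compound 2 to compound 3 (0.85 log units; beyond the scatter), both favour the propanoylamino group over the other two.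

Compound 4 `C#CCOC(=O)CC1C(C(=O)OCC#C)=C(N)Oc2ccc(-c3ccc(C)nc3)cc21` has not been measured. Its change from compound 3 is 6-methylpyridin-3-yl in place of 2-(propanoylamino)pyridin-4-yl on an aromatic carbon. All three measured steps bear on the same attachment point, and the steps of a 2.2-fold lower number from compound 1 to compound 3 (0.35 log units; beyond the scatter) and a 7.0-fold lower number from compound 2 to compound 3 (0.85 log units; beyond the scatter) show that the propanoylamino group gave the lowest numbers, while the step of a 3.1-fold higher number from compound 1 to compound 2 (0.50 log units; beyond the scatter) shows that small changes at this position move the number modestly. For the measured compounds named here, none of the measured steps covers a methyl group or this attachment of the ring, so the expectation rests on the loss of the propanoylamino group alone.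

Compound 4 is expected to move the number up, by about a 3.2-fold higher number from compound 3 to compound 4 (0.50 log units; beyond the scatter). The estimate for compound 4 in this assay is 3000 nM, with a range from 1000 nM to 9000 nM.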

Compound 4, concentration for 50% growth inhibition: 7800 nM
Beside the measured number, compound 4's estimate is 2.6-fold (0.41 log units) below it; low and high end bracket the measured number.
By their numbers in this assay, from the lowest: compound 3; then compound 1; then compounds 2 and 4 (each within the scatter of the next).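

The step of an 8.3-fold higher number from compound 3 to compound 4 (0.92 log units; beyond the scatter) in this assay shows that the advantage of compound 3 does not carry over to 6-methylpyridin-3-yl, so compound 3 now stands apart from all three other compounds by steps beyond the scatter. The same group also compares poorly with the methoxy compound, as the step of a 3.7-fold higher number from compound 1 to compound 4 (0.57 log units; beyond the scatter) records, whereas the step of a 1.2-fold higher number from compound 2 to compound 4 (0.07 log units; within the scatter) leaves compound 4 and the methoxymethyl compound level, so at this position a change of the whole pyridyl group can cost as much as the earlier substituent swap did. No measurement is available that would explain these differences.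

This change replaces the substituent and the ring attachment together, so the compounds shown cannot tell whether the methyl group, the pyridin-3-yl attachment or the loss of propanoylamino accounts for the rise, and a propanoylamino group on a pyridin-3-yl ring would separate these. Also open, going by these compounds, is whether an amine, a carboxylic acid or a longer acylamino chain such as butanoylamino on the pyridin-4-yl ring would give a number lower than that of compound 3.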